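Swapping the aryl on the ketone of a shared core

This account rests on a few compounds, and the source may have more. Where it says the series, first, only, none or still open, it means among the compounds named here.

Of the compounds shown here, two on one core have been measured in a functional assay (aorta) with Rattus norvegicus as the target; a higher number here means a more potent compound, by a factor of ten per unit of this negative logarithm, a lower number a less potent compound. Compound 1 `COc1ccc(C(=O)c2ccc3c(c2)C(n2ccccc2=O)=CC(C)(C)O3)cc1` gives 6.15, and compound 2 `CC1(C)C=C(n2ccccc2=O)c2cc(C(=O)c3ccc([N+](=O)[O-])cc3)ccc2O1` gives 6.2. Within the data shown here, the single step between them, a number 0.05 log units higher from compound 1 to compound 2 (within the scatter), is the whole of what the measurements so far show, so compound 2 and compound 1 sit within the scatter of each other and neither can be set above the other.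

Compound 3 `CC1(C)C=C(n2ccccc2=O)c2cc(C(=O)c3ccccc3C(F)(F)F)ccc2O1` differs from compound 2 in one place: 2-(trifluoromethyl)phenyl in place of 4-nitrophenyl on a carbonyl carbon. Among the measured compounds shown here, the one measured step that touches the same part of the molecule is a number 0.05 log units higher from compound 1 to compound 2 (within the scatter), where a group on the ring attached to the carbonyl carbon was exchanged and nothing beyond the scatter followed. For the measured compounds named here, the present change swaps the whole aromatic group at that carbonyl carbon, and no measured pair matches it, so the expectation rests on that single small step alone. Compound 3 is therefore expected to stay near compound 2, an estimated step of a number 0.10 log units lower from compound 2 to compound 3 (within the scatter), with a wider uncertainty than the scatter itself. The estimate for compound 3 is 6.1, within 5.4 to 6.8.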

Compound 3, logarithm of the reciprocal of the active concentration, log(1/C): 6.76
The estimate for compound 3 lay 0.66 log units below the measured number, within the range that was stated.
By their numbers in this assay, from the lowest: compounds 1 and 2 (each within the scatter of the next); then compound 3.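

In this assay, the aryl group on the carbonyl carbon proves able to move the number: 2-(trifluoromethyl)phenyl in place of 4-nitrophenyl gives a number 0.56 log units higher from compound 2 to compound 3 (beyond the scatter), whereas the earlier exchange on that ring had stayed within the scatter. Set against the methoxy-bearing ring, the same group gives a number 0.61 log units higher from compound 1 to compound 3 (beyond the scatter), so compound 3 stands clear of both compound 1 and compound 2, and a position that had looked flat on the strength of two compounds is shown to be one where the aromatic group counts. The data offer no measurement that could explain this rise, and nothing given here bears on what lies behind it.

The change replaced the whole aromatic group, so the compounds shown do not separate the contribution of the trifluoromethyl group itself from that of where it sits on the ring. From the compounds shown here alone, whether a plain phenyl, or a phenyl carrying a chlorine atom or a nitrile, would fall with compound 3 or with compound 1 and compound 2 remains open.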